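A few compounds are considered here, and "the series" means these few. Any claim that something is new, unique, unknown or untested is made for them only; others in the source may bear on it.

Measured so far in an ADME assay on BJ cells (Homo sapiens) for antiproliferative activity, with a stated time of 72 h; on this read-out lower numbers stand for an effect already at smaller amounts and higher numbers for an effect only at larger amounts of compound:
compound 1 `COc1ccc(-c2cc(=O)c3c(OC)cc(OC)cc3n2C)cc1`: 68000 nM
compound 2 `COc1ccc(-c2cc(=O)c3c(OC)cc(OC)cc3n2S(=O)(=O)c2ccc([N+](=O)[O-])cc2)cc1`: > 29300 nM, a limit of the assay, not a number
compound 3 `COc1ccc(-c2cc(=O)c3c(OC)cc(OC)cc3n2S(=O)(=O)c2cccc([N+](=O)[O-])c2)cc1`: > 39600 nM, a limit of the assay, not a number

Among the compounds with values here, compound 1 is the only member of the series with a measured number in this assay. For compound 2 this assay reports only the limit > 29300 nM. For compound 3 this assay likewise reports only the limit > 39600 nM. Compound 3 therefore stands at one of the two limits, (the limit of > 39600 nM in this assay, at which 1 of the 3 values shown sits), while compound 2 sits at the other, (the limit of > 29300 nM in this assay, at which 1 of the 3 values shown sits). Within the data shown here, the one step connecting the two sulfonyl compounds, a step that the two limits leave unreadable from compound 2 to compound 3, is left unreadable by these limits.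

Compound 4 `COc1ccc(-c2cc(=O)c3c(OC)cc(OC)cc3n2S(=O)(=O)c2ccc(F)cc2)cc1` differs from compound 3 in one place: 4-fluorophenyl in place of 3-nitrophenyl on a sulfonyl sulfur. Among the measured compounds shown here, the only measured step that bears on a change of the aryl group on the sulfonyl sulfur is a step that the two limits leave unreadable from compound 2 to compound 3, whose size cannot be read. For the measured compounds named here, no measured step thus sets a direction or size for this assay here. Compound 4 is expected to come out at 50000 nM, within a range from 15000 nM to 200000 nM, most likely again as a limit. The expected step from compound 3 to compound 4 is a step that the limit leaves unreadable from compound 3 to compound 4.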

Compound 4, half-maximal effective concentration: > 65500 nM
Compound 4: a limit, no number; the forecaster's own chance of this, stated with the estimate: 70%; at least 1.3-fold (0.11 log units) between middle value and limit.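

Compound 4 gives > 65500 nM, a limit of the assay and not a number. Its steps from compound 1, compound 2 and compound 3 cannot be read. Still open, as far as these compounds go, is how compound 2, compound 3 and compound 4 rank against each other and against compound 1 in this assay.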